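The compounds below may be only part of what the source reports. "The series", "measured", "known", "first", "only" and "open" are said of these compounds alone.

Measured compounds in a functional assay on MKN-45 cells (Homo sapiens) for cytotoxicity, read by MTT assay, with a stated time of 72 h; a higher number here means a weaker inhibitor, a lower number a stronger inhibitor:
compound 1 `COc1ccc(OC)c(/C=N/NC(=O)Nc2ccc(Oc3ccnc(-c4nncn4CCN(C)C)c3)c(F)c2)c1` gives 1510 nM
compound 2 `CN(C)CCn1cnnc1-c1cc(Oc2ccc(NC(=O)N/N=C/c3ccc(O)c(Br)c3)cc2F)ccn1` gives 1860 nM
compound 3 `CN(C)CCn1cnnc1-c1cc(Oc2ccc(NC(=O)N/N=C/c3ccc(O)c(O)c3)cc2F)ccn1` gives 3240 nM

Compound 1 holds the lowest of the three numbers in this assay, though its separation from compound 2 is a 1.2-fold higher number from compound 1 to compound 2 (0.09 log units; within the scatter) and from compound 3 is a 2.1-fold higher number from compound 1 to compound 3 (0.33 log units; beyond the scatter). Compound 4 `CN(C)CCn1cnnc1-c1cc(Oc2ccc(NC(=O)N/N=C/c3cc(Br)c(O)c(Br)c3)cc2F)ccn1` has not yet been measured. It differs from compound 1 in one place: 3,5-dibromo-4-hydroxyphenyl in place of 2,5-dimethoxyphenyl on a carbon with a double bond to nitrogen.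

Within the data shown here, two measured steps bear on this change. Both replace the 2,5-dimethoxyphenyl with a hydroxylated phenyl on the same carbon, and both moved the number only slightly upward: a 1.2-fold higher number from compound 1 to compound 2 (0.09 log units; within the scatter) and a 2.1-fold higher number from compound 1 to compound 3 (0.33 log units; beyond the scatter). The bromo-for-hydroxy comparison is a 1.7-fold higher number from compound 2 to compound 3 (0.24 log units; within the scatter). The change to compound 4 is closest to the change made in compound 2, with one more bromine. The step expected for compound 4 in this assay is therefore small, at most a modest rise, a 1.3-fold higher number from compound 1 to compound 4 (0.10 log units; within the scatter). Compound 4 is estimated at 1900 nM, with a range from 900 nM to 4000 nM.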

Compound 4, half-maximal inhibitory concentration: 4320 nM
The estimate for compound 4 lay 2.3-fold (0.36 log units) below the measured number, and the stated range ends below it.
By their numbers in this assay, from the lowest: compounds 1, 2, 3 and 4 (each within the scatter of the next, the first and the last beyond it).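

In this assay, bromo in place of hydrogen on an aromatic carbon gives a 2.3-fold higher number from compound 2 to compound 4 (0.37 log units; beyond the scatter), which shows that one added bromine on the group at this position can move the number beyond the scatter. The full exchange of 2,5-dimethoxyphenyl for 3,5-dibromo-4-hydroxyphenyl gives a 2.9-fold higher number from compound 1 to compound 4 (0.46 log units; beyond the scatter), making compound 4 the second compound, after compound 3, to lie beyond the scatter from compound 1. Set against the 3,4-dihydroxyphenyl group, the new group gives a 1.3-fold higher number from compound 3 to compound 4 (0.12 log units; within the scatter), so this assay does not separate these two groups.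

No measurement at hand accounts for any of these steps. Going by these compounds, it remains open whether a chloro or a carboxylic acid in place of a bromo on this ring would leave the number close to that of compound 2 or move it as the second bromine did.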